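Taking one bromo away from compound 1

A few compounds are considered here, and "the series" means these few. Any claim that something is new, unique, unknown or untested is made for them only; others in the source may bear on it.

Going by the values given here, in a functional assay on SK-N-SH cells (Homo sapiens) for cytotoxicity, read by MTT assay, with a stated time of 24 h (on this read-out lower numbers stand for stronger inhibition and higher numbers for weaker inhibition), compound 1 (`O=c1nc2ccc(Br)cn2cc1Cc1ccc(Br)cc1`) gives 870 nM and this is the only actual number available so far. In this assay compound 2 (`O=C1N=C2C=CC=CN2CC1C(O)c1cccs1`) is recorded only as a limit, > 1000000 nM and not as a number, so it offers no measured gap to compound 1.

Compound 3 (`O=c1nc2ccc(Br)cn2cc1Cc1ccccc1`) keeps the core of compound 1 and carries hydrogen in place of bromo on an aromatic carbon of a six-membered aromatic ring of carbon only, para to a large group (hydrogen in place of bromo on an aromatic carbon). Among the compounds with values here, no measured pair shows this change on its own, so its size in this assay cannot be read from the data. Starting from compound 1 at 870 nM as the only anchor, a moderate shift towards weaker inhibition, meaning a higher number, is expected, although a result within the usual scatter would be no surprise. The expected change is a 2.3-fold higher number from compound 1 to compound 3 (0.36 log units; beyond the scatter) and it remains an estimate. The estimate for compound 3 is 2000 nM with 600 nM to 10000 nM as the expected range.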

Compound 3, half-maximal inhibitory concentration: 137000 nM
Beside the measured number, compound 3's estimate is 69-fold (1.84 log units) below it; the measured number lies above the stated range.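

In this assay, the bromo on an aromatic carbon of the six-membered aromatic ring of carbon only, para to a large group, proves to matter far more than compound 1 alone could reveal: hydrogen in its place gives a 160-fold higher number from compound 1 to compound 3 (2.20 log units; beyond the scatter). The change removes a single bromine atom and involves no ring, no hydrogen-bond donor or acceptor and no net charge, yet this one place accounts for a large step on the shared core. Compound 3 still gives a real number, while compound 2 is recorded only as a limit of the assay: the limit of > 1000000 nM in this assay, at which 1 of the 3 values shown sits.

The compounds shown hold only bromo and hydrogen at this place, so it stays open whether chloro, methyl, methoxy or an amine there would read close to compound 1 or close to compound 3, and the data give no reason for the size of the step. The second bromo, on the shared core, is present in both compound 1 and compound 3, so what it contributes cannot be read from this pair.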